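The source may hold more compounds than are shown below. What is called first, only, known or untested is meant among the compounds shown, and "the series" means these compounds.

Values so far in a physicochemical assay for acid dissociation, read by spectrophotometry, are:

compound 1 `CCOc1cc(CN2CCC(NC(=O)c3cncc(C)c3)CC2)cc(OCC)c1-c1ccc(F)cc1` gives 7.69
compound 2 `CCOc1cc(CN2CCC(NC(=O)c3cncc(C)c3)CC2)ccc1C` gives 8.08

Of these two, compound 2 stands highest, and compound 1 lies lower by a gap beyond the scatter. Compound 3 (`CCOc1cc(CN2CCC(NC(=O)c3cncc(C)c3)CC2)ccc1-c1ccc(F)cc1`) departs from compound 2 by a single change (4-fluorophenyl in place of methyl on an aromatic carbon), with 4-fluorophenyl in place of methyl on an aromatic carbon. Within the data shown here, no step between measured compounds isolates this change. Among the measured compounds shown here, the only guide is compound 1, which also carries 4-fluorophenyl and gives 7.69 against compound 2 at 8.08 but differs from compound 2 in more than that one place. A small downward step is therefore expected in this assay and it may not pass beyond the scatter. The estimated change a number 0.18 log units lower from compound 2 to compound 3 (within the scatter) is a modest fall. For compound 3 the estimate is 7.9 with an expected range from 7.62 to 8.15 when it is measured.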

Compound 3, acid dissociation constant: 7.87
Compound 3: the middle estimate sits 0.03 log units above what was measured; the range from low to high includes it.
By their numbers in this assay, from the lowest: compounds 1, 3 and 2 (each within the scatter of the next, the first and the last beyond it).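

In this assay, the exchange of methyl for 4-fluorophenyl on this aromatic carbon, ortho to an ethoxy group, can now be read on its own as a number 0.21 log units lower from compound 2 to compound 3 (within the scatter) and does not separate the two compounds. Hydrogen in place of ethoxy on an aromatic carbon also has a step of its own, a number 0.18 log units higher from compound 1 to compound 3 (within the scatter), so neither single change passes beyond the scatter at its position. No measurement shown bears on what lies behind these two steps.

The compounds shown leave open whether another group on this carbon, such as an amine, a carboxylic acid or a longer alkoxy chain, would move the read-out beyond the scatter. They also leave open whether methyl and 4-fluorophenyl would stand as close together on a core that carries a second ethoxy group.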